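Swapping the Aryl Group on a Shared Quinazoline Amine

The source may report more compounds than this note shows. Statements on the series, on what has been measured and on what is new or still open speak of the compounds shown alone.

Compound 1 `C=CC(=O)Nc1cccc(NC(=O)CSc2nc(Nc3ccccc3C)c3ccccc3n2)c1`: 30200 nM
Compound 2 `C=CC(=O)Nc1cccc(NC(=O)CSc2nc(Nc3ccc(F)cc3)c3ccccc3n2)c1`: 8290 nM

Both were measured in a functional assay on MGC-803 cells (Homo sapiens) for inhibition, read by MTT assay, with a stated time of 72 h; a higher number here means a weaker inhibitor, a lower number a stronger inhibitor. Among the measured compounds shown here, compound 2 has the lower of the two numbers; the only measured step, a 3.6-fold lower number from compound 1 to compound 2 (0.56 log units; beyond the scatter), came with 4-fluorophenyl in place of 2-methylphenyl on a nitrogen on an aromatic ring. Compound 3 `C=CC(=O)Nc1cccc(NC(=O)CSc2nc(Nc3cc(OC)c(OC)c(OC)c3)c3ccccc3n2)c1` is not yet measured and differs from compound 2 by 3,4,5-trimethoxyphenyl in place of 4-fluorophenyl on a nitrogen on an aromatic ring. For the measured compounds named here, only that one step bears on this change, and it was modest, so a shift of similar size or none beyond the scatter is expected, in either direction. Compound 3 is estimated at 7000 nM, within 1800 nM to 28000 nM, which is expected to mean a 1.2-fold lower number from compound 2 to compound 3 (0.07 log units; within the scatter).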

Compound 3, half-maximal inhibitory concentration: > 50000 nM
Compound 3 gave a limit, no number (the forecaster's own chance of this, stated with the estimate: 5%); at least 7.1-fold (0.85 log units) between middle value and limit.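

This position does not only tolerate change: the 3,4,5-trimethoxyphenyl group brings a clear loss in this assay, with an at least 6.0-fold higher number from compound 2 to compound 3 (0.78 log units; beyond the scatter). Compound 3 gives a limit of the assay, not a number: the limit of > 50000 nM in this assay, at which 1 of the 3 values shown sits. Against the 2-methylphenyl group, the change gives an at least 1.6-fold higher number from compound 1 to compound 3 (0.21 log units; that floor lies within the scatter), so compound 3 cannot be firmly ranked behind compound 1.

On these data alone, how far compound 3 truly lies from the other two remains open. So does whether a smaller group on this phenyl ring, such as an amine or a single chlorine atom, would match compound 2.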